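The source may hold more compounds than are shown below. What is called first, only, known or untested is meant among the compounds shown, and "the series" means these compounds.

Compound 3 `COc1cccc(-c2nc(N)c3nc(-c4ccccc4)sc3n2)c1` stands highest of the three numbers in an assay on CHO cells for displacement of a labelled ligand from adenosine receptor A1 (Homo sapiens), read by scintillation counting, with a stated time of 3 h (on this read-out lower numbers stand for stronger inhibition and higher numbers for weaker inhibition), at 176 nM. Compound 1 `Cc1nc(N)c2nc(-c3ccccc3)sc2n1` gives 34 nM and compound 2 `Nc1nc(-c2ccc(CO)cc2)nc2sc(-c3ccccc3)nc12` gives 82 nM. Compound 4 `Cc1ccc(-c2nc(N)c3nc(-c4ccccc4)sc3n2)o1` differs from compound 3 by 5-methylfuran-2-yl in place of 3-methoxyphenyl on an aromatic carbon. For the measured compounds named here, the steps that bear on this carbon are a 5.2-fold higher number from compound 1 to compound 3 (0.71 log units; beyond the scatter) and a 2.1-fold higher number from compound 2 to compound 3 (0.33 log units; beyond the scatter), with a 2.4-fold higher number from compound 1 to compound 2 (0.38 log units; beyond the scatter) for comparison; every change here moved the number beyond the scatter, the methyl giving the lowest number and the two aryl groups higher ones. Nothing measured shows a five-membered aromatic ring at this place, so the expectation rests on an interpolation between compound 1 and compound 3, giving a modest step down, a 2.2-fold lower number from compound 3 to compound 4 (0.34 log units; beyond the scatter). Compound 4 is therefore estimated at 80 nM, within a range of 30 nM to 250 nM.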

Compound 4, inhibition constant: 28.9 nM
For compound 4 the middle estimate is 2.8-fold (0.44 log units) above the measured one; the whole stated range lies above it.
By their numbers in this assay, from the lowest: compounds 4 and 1 (each within the scatter of the next); then compound 2; then compound 3.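

In this assay, a ring on this carbon between two ring nitrogen atoms need not raise the number over methyl, as shown by a 1.2-fold lower number from compound 1 to compound 4 (0.07 log units; within the scatter) for 5-methylfuran-2-yl in place of methyl. With a 6.1-fold lower number from compound 3 to compound 4 (0.78 log units; beyond the scatter) and a 2.8-fold lower number from compound 2 to compound 4 (0.45 log units; beyond the scatter) against the aryl groups, the higher numbers of compound 2 and compound 3 go with those two groups, not with every ring here. No evidence on the origin of these steps is at hand. As far as these compounds go, whether the furan oxygen or its methyl matters more stays open, as does how an amine, a carboxylic acid or a longer chain here would read.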